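The source may report more compounds than this note shows. Statements on the series, on what has been measured and on what is new or still open speak of the compounds shown alone.

Compound 1 `O=C(NCCCCc1ccccc1)c1cccc(C2SCC(=O)N2c2cccc(F)c2)c1`: 32.4 nM
Compound 2 `Cc1ccnc(N2C(=O)CS[C@H]2c2cccc(C(=O)NCCCCn3cccn3)c2)c1`: > 10000 nM

Among the compounds with values here, in a functional assay on HOS-TE85 cells (Homo sapiens) for inhibition, read by CCK-8 assay, with a stated time of 72 h (on this read-out lower numbers stand for stronger inhibition and higher numbers for weaker inhibition), compound 1 gives 32.4 nM, the only outright number among the values shown. Compound 2 reaches only a limit of the assay, > 10000 nM, which is the limit of > 10000 nM in this assay, at which 1 of the 2 values shown sits. Compound 3 `COc1ccc(F)cc1N1C(=O)CSC1c1cccc(C(=O)NCCCCc2ccccc2)c1` differs from compound 1 in one place: methoxy in place of hydrogen on an aromatic carbon. Within the data shown here, no pair of measured compounds differs in a single place, so this step has no direct precedent here. Any change in this assay is expected to be modest, not clearly beyond the scatter. Compound 3 is estimated at 50 nM, between 15 nM and 200 nM, an expected step of a 1.5-fold higher number from compound 1 to compound 3 (0.19 log units; within the scatter).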

Compound 3, half-maximal inhibitory concentration in the HOS-TE85 assay: 8.8 nM
For compound 3 the middle estimate is 5.7-fold (0.75 log units) above the measured one; measured number below the stated range.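

In the HOS-TE85 assay, methoxy in place of hydrogen, turning 3-fluorophenyl into 5-fluoro-2-methoxyphenyl, gives a 3.7-fold lower number from compound 1 to compound 3 (0.57 log units; beyond the scatter), so this aromatic carbon accepts a group larger than hydrogen with a gain in inhibition. In a physicochemical assay for solubility, read by turbidimetry, measured as kinetic solubility, at pH 6.8 (a lower number here means a less soluble compound, a higher number a more soluble compound), compound 1 gives 10000 nM and compound 3 gives 10000 nM, so the two values are the same. Nothing measured here accounts for the gain in inhibition.

From the compounds shown here alone, whether the gain is specific to methoxy stays open: an ethoxy group, a hydroxyl group or a chlorine atom at the same place would test this.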